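This account rests on a few compounds, and the source may have more. Where it says the series, first, only, none or still open, it means among the compounds named here.

Measured compounds:
Compound 1, `CC1=C(C(=O)OC(C)C)[C@@H](c2ccco2)N/C(=N/C#N)N1` — 2%
Compound 2, `CC1=C(C(=O)OC(C)C)C(c2ccco2)N/C(=N/C#N)N1` — 21%

In an assay on cells for displacement of a labelled ligand from adenosine receptor A1 (Homo sapiens), with a stated time of 60 min, tested at 1 uM (a higher number here means more inhibition at the concentration tested (going by the name of the read-out), a lower number less inhibition), compound 2 stands highest of the two numbers, with compound 1 the nearest and a number lower by a number 19 percentage points higher from compound 1 to compound 2 (beyond the scatter). The step from compound 1 to compound 2 differs only in stereochemistry, because the fact that one of compounds 1 and 2 is drawn with a defined configuration and the other without, at the place where they differ one of the two is drawn with a defined configuration at the saturated ring carbon and the other without.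

Compound 3, `CC1=C(C(=O)OC(C)C)[C@H](c2ccco2)N/C(=N/C#N)N1`, is not yet measured in this assay. Its difference from compound 2 is the two compounds have the same atoms and bonds; at least one stereo element is drawn with a configuration in one of them and without one in the other: 1 of 2 stereo elements differ; a stereocentre at a saturated ring carbon is drawn without a configuration in compound 2 and R in compound 3. Within the data shown here, the only measured step that bears on this change is the one from compound 1 to compound 2, which was modest and beyond the scatter; compound 2 without a configuration sits above compound 1 drawn S, so the mirror configuration drawn R in compound 3 is expected to lie on the higher side. A further step upward in this assay is expected for compound 3, of about a number 17 percentage points higher from compound 2 to compound 3 (beyond the scatter). Compound 3 is accordingly estimated at 38%, with a range from 20% to 55%.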

Compound 3, a percentage reported as inhibition, at one concentration (the size of the read-out at that concentration, not a potency): 18%
Compound 3: middle estimate off by 20 percentage points, on the high side, outside the stated range (below it).
By their numbers in this assay, from the lowest: compound 1; then compounds 3 and 2 (each within the scatter of the next).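

In this assay the two drawn forms can now be compared directly, giving a number 16 percentage points higher from compound 1 to compound 3 (beyond the scatter). This step can be attributed to the configuration at the saturated ring carbon alone, because nothing else separates the pair: the fact that compounds 1 and 3 differ only in the configuration as drawn. The form drawn R and the form without a drawn configuration are not told apart, at a number 3 percentage points lower from compound 2 to compound 3 (within the scatter), so the gap seen earlier for the form drawn S now has a counterpart between the two defined forms, while leaving the configuration undrawn gives no separate reading from the form drawn R: the fact that one of compounds 2 and 3 is drawn with a defined configuration and the other without, at the place where they differ.

On these data alone, all three readings come from a single concentration, so they show only the size of the effect at that concentration, and how far apart the two defined forms would lie at other concentrations remains open. As far as these compounds go, it also remains open whether the gap between the forms drawn S and R would persist with an amine or a longer chain in place of the group at the saturated ring carbon.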